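Swapping a methyl for an ethoxy on a kinase inhibitor

This account rests on a few compounds, and the source may have more. Where it says the series, first, only, none or still open, it means among the compounds named here.

Of the compounds shown here, three sharing one core have been tested in an assay on isolated protein for inhibition of Rho-associated protein kinase 1 (Homo sapiens), read by scintillation counting, radiometric assay and 33P incorporation, with a stated time of 40 min, in the presence of a further agent that is not named here; on this read-out lower numbers stand for stronger inhibition and higher numbers for weaker inhibition. Compound 1 `COc1cc(OCC(=O)Nc2cccc(NC(=O)c3ccc(N(C)C)cc3)c2)ccc1C=O` gives 3740 nM. Compound 2 `Cc1c(OCC(=O)Nc2cccc(NC(=O)c3ccc(N(C)C)cc3)c2)ccc2c(=O)ccoc12` returns only a limit, > 10000 nM, which is the limit of > 10000 nM in this assay, at which 1 of the 3 values shown sits. Compound 3 `Cc1ccc(C(=O)Nc2cccc(NC(=O)COc3ccc4c(=O)ccoc4c3)c2)cc1` gives 183 nM, the lowest of the two numbers in this assay, with compound 1 sitting a long way above it, well beyond the scatter.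

Compound 4 `CCOc1ccc(C(=O)Nc2cccc(NC(=O)COc3ccc4c(=O)ccoc4c3)c2)cc1` has not yet been measured. It differs from compound 3 in a single place: ethoxy in place of methyl on an aromatic carbon, para to a large group. For the measured compounds named here, no pair of measured compounds shows the effect of this exact exchange, so the expectation rests on compound 3 alone. A change this small, set on the outer aryl ring, is expected to move the number little, with a step of a 1.4-fold higher number from compound 3 to compound 4 (0.14 log units; within the scatter) that could fall in either direction and may well stay within the scatter. Compound 4 is therefore expected to come in near 250 nM, somewhere between 80 nM and 800 nM.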

Compound 4, half-maximal inhibitory concentration: 17 nM
Beside the measured number, compound 4's estimate is 15-fold (1.17 log units) above it; measured number outside the range, below it.
By their numbers in this assay, from the lowest: compound 4; then compound 3; then compound 1. At a limit, above all of these: compound 2.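

In this assay, ethoxy in place of methyl on an aromatic carbon, para to a large group, gives an 11-fold lower number from compound 3 to compound 4 (1.03 log units; beyond the scatter) and so lies well beyond the scatter. This position is therefore far from indifferent to what it carries, and a modest exchange there, with 1 heavy atom leaving and 3 entering, strengthens inhibition rather than weakening it. Nothing measured for these compounds accounts for the gain.

On these data alone, what stays open is whether the oxygen or the extra length matters more: an ethyl group would keep the length without the oxygen, while a methoxy group would keep the oxygen on a shorter chain. A longer propoxy chain or an amine at the same place would show how far the gain extends.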